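The compounds below may be only part of what the source reports. "The series", "measured", "known", "first", "only" and "open" are said of these compounds alone.

Measured in an assay on CHO cells for displacement of a labelled ligand from melanin-concentrating hormone receptor 1 (Homo sapiens), read by scintillation counting, with a stated time of 1 h; on this read-out lower numbers stand for stronger inhibition and higher numbers for weaker inhibition:
compound 1 `Cc1c(C2CC2)nc2ccc(-n3ccc(OCc4ccc(C(F)(F)F)cc4)cc3=O)cn12` — 72 nM
compound 2 `Cc1c(C2CC2)nc2ccc(-n3ccc(OCc4cccnc4)cc3=O)cn12` — > 1000 nM, a limit of the assay.
compound 3 `Cc1c(C2CC2)nc2ccc(-n3ccc(OCc4cncnc4)cc3=O)cn12` — > 1000 nM, a limit of the assay.

Compound 3 thus has no number of its own in this assay, only (the limit of > 1000 nM in this assay, at which 2 of the 3 values shown sit). The step considered is 5-(trifluoromethyl)thiophen-3-yl in place of pyrimidin-5-yl on a saturated chain carbon bound to an oxygen on an aromatic ring, giving compound 4 `Cc1c(C2CC2)nc2ccc(-n3ccc(OCc4csc(C(F)(F)F)c4)cc3=O)cn12`.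

Among the compounds with values here, two measured steps bear on it. Both run from the trifluoromethyl-bearing aryl of compound 1 to a six-membered two-nitrogen or one-nitrogen ring: an at least 13-fold higher number from compound 1 to compound 3 (1.14 log units; beyond the scatter), and an at least 13-fold higher number from compound 1 to compound 2 (1.14 log units; beyond the scatter). Between the two limited compounds, a step that the two limits leave unreadable from compound 2 to compound 3. Replacing pyrimidin-5-yl with a five-membered ring that again carries a trifluoromethyl group reverses the direction of the change seen from compound 1 to compound 3, so a large decrease in the number is expected in this assay, though the thiophene is not the phenyl of compound 1 and the size of the recovery is uncertain.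

Compound 4 is therefore expected to give about 150 nM in this assay, within 50 nM to 600 nM. That estimate corresponds to an expected at least 6.6-fold lower number from compound 3 to compound 4 (0.82 log units; beyond the scatter).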

Compound 4, half-maximal inhibitory concentration: 17 nM
Compound 4: middle estimate off by 8.8-fold (0.95 log units), on the high side, outside the stated range (below it).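

In this assay, the place on a saturated chain carbon bound to an oxygen on an aromatic ring accepts a five-membered aromatic ring, and the 5-(trifluoromethyl)thiophen-3-yl group gives an at least 58-fold lower number from compound 3 to compound 4 (1.76 log units; beyond the scatter) and an at least 58-fold lower number from compound 2 to compound 4 (1.76 log units; beyond the scatter). Within the data shown here, its result also moves past the 4-(trifluoromethyl)phenyl group, with a 4.2-fold lower number from compound 1 to compound 4 (0.63 log units; beyond the scatter), so a six-membered aromatic ring is not needed here, and among the four compounds, compound 4 is the strongest in this assay, with both trifluoromethyl-bearing compounds giving measured numbers and no compound going against this. The two larger steps are bounds and not exact sizes, as compounds 2 and 3 each stand at a limit of the assay: the limit of > 1000 nM in this assay, at which 2 of the 4 values shown sit.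

As far as these compounds go, the steps from compounds 2 and 3 change the ring and add the trifluoromethyl group together, so the share of each stays open, and a plain thiophen-3-yl or a 5-chlorothiophen-3-yl group would separate them. Also open, from the compounds shown here alone, is how this place responds to a group of another kind, such as an amine, a carboxylic acid or a longer chain ahead of the ring.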